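The source may report more compounds than this note shows. Statements on the series, on what has been measured and on what is new or still open speak of the compounds shown alone.

Working notes on the series. In a functional assay on DLD-1 cells (Homo sapiens) for antiproliferative activity, read by CellTiter-Glo, with a stated time of 72 h (a lower number here means a stronger inhibitor, a higher number a weaker inhibitor), compound 1 `CCc1cc(Br)ccc1S(=O)(=O)N1CCC(N2CCC(C)CC2)CC1` gives 0.6 nM and compound 3 `CC1CCN(C2CCN(S(=O)(=O)c3ccccc3-c3ccccc3)CC2)CC1` gives 0.96 nM. Compound 2 `Cc1cc(C)c(S(=O)(=O)N2CCC(N3CCC(CCC#N)CC3)CC2)c(C)c1` reaches only a limit in this assay, namely > 5000 nM. For compound 2 the relevant line is the limit of > 5000 nM in this assay, at which 1 of the 3 values shown sits. Compound 4 `Cc1cc(C)c(S(=O)(=O)N2CCC(N3CCC(Cc4ccccc4)CC3)CC2)c(C)c1` differs from compound 2 by phenyl in place of cyanomethyl on a saturated chain carbon bound to a saturated ring carbon. Within the data shown here, no step between measured compounds is available for this change, so its size and direction in this assay cannot be read from the data; with compound 2 standing at a limit, a gain of unknown size is possible but not secured. Compound 4 is therefore expected near 500 nM, with a wide range from 20 nM to 5000 nM. The expected step from compound 2 to compound 4 is an at least 10-fold lower number from compound 2 to compound 4 (1.00 log units; beyond the scatter).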

Compound 4, half-maximal inhibitory concentration: 3.5 nM
The estimate for compound 4 lay 140-fold (2.15 log units) above the measured number; the measured number lies below the stated range.
By their numbers in this assay, from the lowest: compounds 1 and 3 (each within the scatter of the next); then compound 4. At a limit, above all of these: compound 2.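

In this assay, among these compounds, phenyl in place of cyanomethyl on a saturated chain carbon bound to a saturated ring carbon gives an at least 1400-fold lower number from compound 2 to compound 4 (3.15 log units; beyond the scatter), the first step and one showing that the number responds strongly to the group at this place. The size of this step is only a bound, as compound 2 stands at a limit: the limit of > 5000 nM in this assay, at which 1 of the 4 values shown sits.

The compounds shown leave open how an amine or a carboxylic acid at this place would compare with phenyl and cyanomethyl. Going by these compounds, whether a longer chain ending in phenyl would keep the number of compound 4 also stays open.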